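This account rests on a few compounds, and the source may have more. Where it says the series, first, only, none or still open, it means among the compounds named here.

Measured in an ADME assay for permeability, using PAMPA, with a stated time of 4 h, at pH 5.5; a lower number here means that the compound crosses the layer more slowly, a higher number that the compound crosses the layer faster:
- compound 1 `NC(=O)NCCCCN(C[C@H]1Cc2ncccc2CN1)[C@H]1CCCc2cccnc21`: 7 nm/s
- compound 2 `NC(=O)NC/C=C\CN(C[C@H]1Cc2ncccc2CN1)[C@H]1CCCc2cccnc21`: 5 nm/s

Compound 2, at 5 nm/s, lies within the scatter of compound 1, at 7 nm/s, so this assay does not separate the two.

The next structure is compound 3 `NC(=O)NC/C=C/CN(C[C@H]1Cc2ncccc2CN1)[C@H]1CCCc2cccnc21`. (the two compounds have the same atoms and bonds and differ only in configuration as drawn: 1 of 3 stereo elements differ; a double bond is drawn Z in compound 2 and E in compound 3). Only the geometry of that double bond is different.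

Within the data shown here, one measured step bears on this change, and only indirectly: a 1.4-fold lower number from compound 1 to compound 2 (0.15 log units; within the scatter). That step replaced one open chain with another of the same heavy-atom count, on a saturated chain carbon bound to an amine nitrogen, and it stayed within the scatter. Among the measured compounds shown here, no measured pair compares a double bond drawn Z with one drawn E, so the size of this particular change remains unknown. For the measured compounds named here, with only that small step as a guide, no shift beyond the scatter is anticipated.

The expected step is a 1.2-fold higher number from compound 2 to compound 3 (0.08 log units; within the scatter). For compound 3 the estimated value is 6 nm/s, with an expected range of 3 nm/s to 12 nm/s.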

Compound 3, apparent permeability: 6 nm/s
Compound 3: middle estimate and measured number agree at the digits printed; the measured number falls inside the stated range.
By their numbers in this assay, from the lowest: compounds 2, 3 and 1 (each within the scatter of the next).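

In this assay, the geometry of the double bond now has a direct reading, a 1.2-fold higher number from compound 2 to compound 3 (0.08 log units; within the scatter), and this pair isolates that one feature: the fact that compounds 2 and 3 differ only in the configuration as drawn. Set against the saturated chain of compound 1, the chain with the double bond drawn E gives a 1.2-fold lower number from compound 1 to compound 3 (0.07 log units; within the scatter), so this chain is not separated from the saturated one either. With the earlier step between compound 1 and compound 2 also within the scatter, this assay separates none of these three chains on the saturated chain carbon bound to an amine nitrogen, whether the chain is saturated or holds a double bond drawn Z or E.

From the compounds shown here alone, whether a longer chain, or a chain carrying an amine or a carboxylic acid, would give a step beyond the scatter stays open. These readings also rest on one shared core and one read-out, so they do not say whether the double bond geometry would separate compounds on another core or in another assay.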